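The compounds below may be only part of what the source reports. "The series", "measured", "known", "first", "only" and "open" are said of these compounds alone.

Among the compounds with values here, compound 2 `CCCCCCc1nc2nc(-c3ccccc3)cc(C(F)(F)F)c2c(=O)n1Cc1cn(CCC(F)(F)C(F)(F)C(F)(F)C(F)(F)C(F)(F)C(F)(F)F)nn1` holds the only number in a functional assay on COLO 205 cells (Homo sapiens) for cytotoxicity, read by MTT assay, with a stated time of 24 h; a higher number here means a weaker inhibitor, a lower number a stronger inhibitor: in this assay compound 2 gives 132 ug/mL. Compound 1 `CCc1nc2nc(-c3ccccc3)cc(C(F)(F)F)c2c(=O)n1Cc1cn(CCC(F)(F)C(F)(F)C(F)(F)C(F)(F)C(F)(F)C(F)(F)C(F)(F)C(F)(F)F)nn1` returns only a limit of the assay, > 200 ug/mL, and no number (the limit of > 200 ug/mL in this assay, at which 1 of the 2 values shown sits). Compound 3 `CCCCCCc1nc2nc(-c3ccccc3)cc(C(F)(F)F)c2c(=O)n1Cc1cn(CCC(F)(F)C(F)(F)C(F)(F)C(F)(F)C(F)(F)C(F)(F)C(F)(F)C(F)(F)F)nn1` is compound 2 with 1,1,2,2,2-pentafluoroethyl in place of fluoro on a saturated chain carbon bound to two fluorine atoms and a saturated chain carbon. Within the data shown here, no step between measured compounds is available here. The longer fluorinated chain is shared with compound 1, which sits at the limit of > 200 ug/mL in this assay, at which 1 of the 2 values shown sits. For compound 3 a modest step toward weaker inhibition, a 1.4-fold higher number from compound 2 to compound 3 (0.13 log units; within the scatter), is therefore expected. Compound 3 is estimated at 180 ug/mL, between 100 ug/mL and 320 ug/mL, with a real chance of only a limit being reported.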

Compound 3, half-maximal inhibitory concentration: > 200 ug/mL
Compound 3 ended at the assay's limit (the forecaster's own chance of this, stated with the estimate: 45%); middle value at least 1.1-fold (0.04 log units) away from the limit.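

In this assay, 1,1,2,2,2-pentafluoroethyl in place of fluoro on a saturated chain carbon bound to two fluorine atoms and a saturated chain carbon gives an at least 1.5-fold higher number from compound 2 to compound 3 (0.18 log units; that floor lies within the scatter). Compounds 1 and 3 both return limits, so the step between them, butyl in place of hydrogen, cannot be read. This change is therefore bounded from one side only, and most of the series gives no number: the limit of > 200 ug/mL in this assay, at which 2 of the 3 values shown sit.

From the compounds shown here alone, the true size of the step stays open. Also open, going by these compounds, is whether a shorter fluorinated chain or a terminal amine at this position gives a number in this assay.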